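The source may report more compounds than this note shows. Statements on the series, on what has been measured and on what is new or still open speak of the compounds shown alone.

Working notes on the series, a functional assay on HeLa cells (Homo sapiens) for inhibition, read by MTT assay, with a stated time of 48 h; on this read-out higher numbers stand for weaker inhibition and lower numbers for stronger inhibition.

Of the compounds shown here, three sharing one core have numbers so far. Compound 1 `CCOC(=O)C1=C(N/N=C(\C#N)C(N)=O)Nc2[nH]nc(C)c2C1c1ccc(N(C)C)cc1` gives 47300 nM, compound 2 `CCOC(=O)C1=C(N/N=C(/Cl)C#N)Nc2[nH]nc(C)c2C1c1ccc(N(C)C)cc1` gives 26200 nM, and compound 3 `CCOC(=O)C1=C(N/C=N/c2ccc(C)cc2)Nc2[nH]nc(C)c2C1c1ccc(N(C)C)cc1` gives 43200 nM. Compound 3 stands second highest of the three numbers; the nearest is compound 1, with a 1.1-fold lower number from compound 1 to compound 3 (0.04 log units; within the scatter), and the furthest is compound 2, with a 1.6-fold higher number from compound 2 to compound 3 (0.22 log units; within the scatter). Among the measured compounds shown here, the one step among the chain-bearing pair, a 1.8-fold lower number from compound 1 to compound 2 (0.26 log units; within the scatter), also lies within the scatter, so the three numbers are not separated.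

Compound 4 `CCOC(=O)C1=C(N/N=C(/C#N)C(=O)OCC)Nc2[nH]nc(C)c2C1c1ccc(N(C)C)cc1` is the next one. The change from compound 3: a group of 9 heavy atoms (5 carbon, 2 nitrogen, 2 oxygen; no ring) in place of a group of 9 heavy atoms (8 carbon, 1 nitrogen; one six-membered aromatic ring of carbon only), on an amine nitrogen. The entering group, like those of compound 1 and compound 2, has no ring, and all three steps connecting those two to compound 3 were within the scatter, so no step beyond the scatter is expected here; the expected step is a 1.2-fold lower number from compound 3 to compound 4 (0.09 log units; within the scatter), which amounts to no real movement. Compound 4 is therefore expected to give about 35000 nM, with a range from 15000 nM to 80000 nM.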

Compound 4, half-maximal inhibitory concentration: 39200 nM
Compound 4: middle estimate off by 1.1-fold (0.05 log units), on the low side; low and high end bracket the measured number.
By their numbers in this assay, from the lowest: compounds 2, 4, 3 and 1 (each within the scatter of the next).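

In this assay, the ringless group of 9 heavy atoms in compound 4 takes the place of the group with one six-membered aromatic ring on the amine nitrogen, and the two are not separated (a 1.1-fold lower number from compound 3 to compound 4 (0.04 log units; within the scatter)). Among the compounds shown here, this is the first direct comparison of that ring with a ringless group of the same heavy-atom count, and the entering group, with 4 hydrogen-bond acceptors against 1, is also not separated from the other two ringless groups (a 1.5-fold higher number from compound 2 to compound 4 (0.17 log units; within the scatter); a 1.2-fold lower number from compound 1 to compound 4 (0.08 log units; within the scatter)). All four groups at this position therefore remain within the scatter of one another, and no supporting evidence bears on this result.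

Going by these compounds, whether a carboxylic acid or a longer alkyl chain on this amine nitrogen would give a number beyond the scatter of these four remains open. Also open, on these data alone, is whether any change elsewhere on the shared core would do so.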